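From compound 2 to compound 3: amide substituent change

The source may report more compounds than this note shows. Statements on the series, on what has been measured and on what is new or still open speak of the compounds shown alone.

In an ADME assay on microsomes from liver (Mus musculus, strain CD-1) for metabolic stability, read by LC-MS, tested at 2 uM (a lower number here means that the compound disappears faster, a higher number that the compound lasts longer), compound 1 `CN1CCC(NS(=O)(=O)c2ccccc2Nc2cc(-c3ccc4ccn(C)c4c3)c3nccnc3c2)C1` gives 0.667 h and compound 2 `Cn1ccc2ccc(-c3cc(Nc4cnccc4C(=O)NCc4cncnc4)cc4nccnc34)cc21` gives 0.4 h within the scatter of compound 1. The change to compound 3 `CC(=O)N1CCCC(NC(=O)c2ccncc2Nc2cc(-c3ccc4ccn(C)c4c3)c3nccnc3c2)C1` is 1-acetylpiperidin-3-yl in place of (pyrimidin-5-yl)methyl on an amide-type nitrogen and puts 1-acetylpiperidin-3-yl in place of (pyrimidin-5-yl)methyl on an amide-type nitrogen. Within the data shown here, no measured pair isolates this change, so the expected step of a 1.3-fold higher number from compound 2 to compound 3 (0.10 log units; within the scatter) in this assay is none beyond the scatter. As a half-life, compound 3 is estimated at 0.5 h with an expected range of 0.2 h to 1.2 h in these notes.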

Compound 3, half-life: 0.4 h
For compound 3 the middle estimate is 1.3-fold (0.10 log units) above the measured one, within the range that was stated.
By their numbers in this assay, from the lowest: compounds 2, 3 and 1 (each within the scatter of the next).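

Among these compounds, compound 2 and compound 3 form the one pair here that differs in a single place, so this amide-type nitrogen can be read directly in this assay: 1-acetylpiperidin-3-yl in place of (pyrimidin-5-yl)methyl gives no change at the digits printed from compound 2 to compound 3 (within the scatter). An aromatic ring with two hetero atoms and a non-aromatic ring with one hetero atom are therefore not separated at this place by this read-out. Nothing at hand offers an explanation for this result.

Open, on these data alone, is whether an amine, a carboxylic acid or a longer chain on this nitrogen would give a step beyond the scatter. Also open, as far as these compounds go, is whether this step holds on any other core.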